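The source may report more compounds than this note shows. Statements on the series, on what has been measured and on what is new or still open speak of the compounds shown alone.

Measured compounds:
compound 1, `N#Cc1cccc(F)c1-c1nc2ncccc2o1`, 50%
compound 2, `O=[N+]([O-])c1ccccc1-c1nc2cccnc2o1`, 57%

In a functional assay on the whole organism for inhibition, with Rattus norvegicus as the target, at a dose of 30 mg/kg (on this read-out lower numbers stand for less inhibition and higher numbers for more inhibition at the one dose given (going by the name of the read-out)), compound 1 gives 50%. In this assay compound 2 gives 57%. Compound 1 has the lower of the two numbers, but the gap to compound 2 lies within the usual scatter of repeated measurements, so the two cannot be told apart on these data.

Compound 3, `N#Cc1ccccc1-c1nc2ncccc2o1`, has not been measured yet. It differs from compound 1 in a single place: hydrogen in place of fluoro on an aromatic carbon. Among the measured compounds shown here, no pair of measured compounds shows what this kind of change does in this assay, so there is no measured step to lean on. Because compound 1 sits at 50% with only a fluoro removed, the step of a number 5 percentage points lower from compound 1 to compound 3 (within the scatter) is expected to be small and to stay within the scatter. Compound 3 is therefore estimated at 45%, with a range from 25% to 65%.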

Compound 3, a percentage reported as inhibition, in the whole organism at one dose (the size of the read-out at that dose, not a potency): 62%
Estimate against measurement, compound 3: 17 percentage points below; the measured number falls inside the stated range.
By their numbers in this assay, from the lowest: compounds 1, 2 and 3 (each within the scatter of the next, the first and the last beyond it).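

In this assay, hydrogen in place of fluoro on this aromatic carbon gives a number 12 percentage points higher from compound 1 to compound 3 (beyond the scatter). This position is therefore not indifferent to what it carries, and the fluoro of compound 1 is not needed for the inhibition seen at this one dose, since compound 3 reads higher without it. Nothing available explains the direction of this step, so it stands as an observation only.

With only fluoro and hydrogen compared here, the compounds shown leave open how this carbon would respond to other groups, such as chloro, methoxy or an amine. They also leave open whether the same change would give a similar step in a compound that carries something other than the cyano group on this ring.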